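The compounds below may be only part of what the source reports. "The series", "measured", "known", "first", "only" and "open" are said of these compounds alone.

Measured so far:
- compound 1 `Oc1ccc(-c2ccc(-c3ccc(-c4nc5ccccc5[nH]4)cc3)cc2)cc1` gives 100000 nM
- compound 2 `CN(C)c1ccc(-c2ccc(-c3ccc(-c4nc5ccccc5[nH]4)cc3)cc2)cc1` gives 100000 nM

For the measured compounds named here, in a functional assay on ZR-75-1 cells (Homo sapiens) for inhibition, read by sulforhodamine B assay (on this read-out higher numbers stand for weaker inhibition of growth and lower numbers for stronger inhibition of growth), compound 2 stands at 100000 nM and is level with compound 1, its only measured neighbour. The next structure is compound 3 `CN(C)c1ccc(-c2ccc(-c3ccc(-c4nc5c(O)cccc5[nH]4)cc3)cc2)cc1`, which carries hydroxy in place of hydrogen on an aromatic carbon, turning 1H-benzimidazol-2-yl into 4-hydroxy-1H-benzimidazol-2-yl: hydroxy in place of hydrogen on an aromatic carbon. Going by the values given here, only one measured step bears on this change, and only indirectly, since it lies at a different place in the structure. That step is no change at the digits printed from compound 1 to compound 2 (within the scatter), with dimethylamino in place of hydroxy on an aromatic carbon. Among the compounds with values here, no measured compound carries a substituent at the new place, so the evidence is thin. No step beyond the scatter is expected in this assay, though a move towards stronger inhibition of growth cannot be excluded. The estimated step is a 1.4-fold lower number from compound 2 to compound 3 (0.15 log units; within the scatter). For compound 3 the expected value is 70000 nM, within an estimated range of 15000 nM to 150000 nM.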

Compound 3, concentration for 50% growth inhibition: 4100 nM
For compound 3 the middle estimate is 17-fold (1.23 log units) above the measured one; the whole stated range lies above it.
By their numbers in this assay, from the lowest: compound 3; then compounds 1 and 2 (each within the scatter of the next).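

Hydroxy in place of hydrogen, giving the 4-hydroxy-1H-benzimidazol-2-yl group, is the only step beyond the scatter among the compounds shown in this assay (a 24-fold lower number from compound 2 to compound 3 (1.39 log units; beyond the scatter)), whereas dimethylamino in place of hydroxy at the other place gave none (no change at the digits printed from compound 1 to compound 2 (within the scatter)). The series therefore responds to a substituent on this six-membered aromatic ring of carbon only, a place the earlier pair left untouched. Nothing measured here accounts for the size of the step.

Going by these compounds, whether the step needs hydroxy itself, or would also appear with methoxy, an amine or fluorine at the same place, remains open. Also open, on these data alone, is whether the same hydroxy gives a step of this size on the core of compound 1, which carries hydroxy in place of dimethylamino.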